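The source may hold more compounds than are shown below. What is called first, only, known or untested is meant among the compounds shown, and "the series" means these compounds.

Compound 1 `N#CC1=C(N)Oc2c(c3nc4ccccc4nc3c3ccccc23)C12C(=O)N(Cc1cnnn1-c1ccc(F)cc1)c1ccccc12` is known in an ADME assay on L02 cells (Homo sapiens) for antiproliferative activity, read by MTT assay, with a stated time of 48 h (on this read-out lower numbers stand for stronger inhibition and higher numbers for weaker inhibition), only as a limit: compound 1 gives > 50000 nM. Compound 2 `N#CC1=C(N)Oc2c(c3nc4ccccc4nc3c3ccccc23)C12C(=O)N(Cc1cnnn1-c1ccc([N+](=O)[O-])cc1)c1ccccc12` likewise sits at a limit, > 50000 nM. Compound 3 `N#CC1=C(N)Oc2c(c3nc4ccccc4nc3c3ccccc23)C12C(=O)N(Cc1cnnn1-c1cccc(S(N)(=O)=O)c1)c1ccccc12` also reaches only a limit, > 50000 nM. The steps a step that the two limits leave unreadable from compound 1 to compound 2 and a step that the two limits leave unreadable from compound 1 to compound 3 are therefore of unknown size, as is a step that the two limits leave unreadable from compound 2 to compound 3; all three values share (the limit of > 50000 nM in this assay, at which 3 of the 3 values shown sit). Compound 4 `Cc1ccc(-n2nncc2CN2C(=O)C3(C(C#N)=C(N)Oc4c3c3nc5ccccc5nc3c3ccccc43)c3ccccc32)cc1C` differs from compound 1 by 3,4-dimethylphenyl in place of 4-fluorophenyl on an aromatic nitrogen. Going by the values given here, no measured step at this position resolves into a number, so the change to the aryl group on the ring nitrogen is expected to give no step readable beyond the scatter. For compound 4 the expected value is 50000 nM, within 20000 nM to 200000 nM, most likely reported again as a limit. The step of a number no higher from compound 1 to compound 4 (the limit leaves the size open) is thus expected to be flat.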

Compound 4, half-maximal inhibitory concentration: > 50000 nM
Compound 4: a limit, no number; the forecaster's own chance of this, stated with the estimate: 85%; the middle value lies on the limit itself.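

In this assay compound 4 gives > 50000 nM, a limit, so its steps from compound 1, compound 2 and compound 3 cannot be read: the limit of > 50000 nM in this assay, at which 4 of the 4 values shown sit.
The compounds shown leave open how the four compounds rank and whether any aryl group on this ring nitrogen gives a readable number.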